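This account rests on a few compounds, and the source may have more. Where it says the series, first, only, none or still open, it means among the compounds named here.

Compound 1, `Cc1cc(C#N)cc(C)c1Oc1ccnc(S(=O)(=O)CC(=O)Nc2ccccc2)n1`: 29300 nM
Compound 2, `Cc1ccc(NC(=O)CS(=O)(=O)c2nccc(Oc3c(C)cc(C#N)cc3C)n2)cc1C`: 13900 nM

Both numbers come from an ADME assay on MT4 cells (Homo sapiens) for cytotoxicity, read by MTT assay, with a stated time of 4 days; on this read-out higher numbers stand for lower toxicity in this test and lower numbers for higher toxicity in this test. Compound 1 stands highest of the two measured values; its nearest neighbour is compound 2, reached by a 2.1-fold lower number from compound 1 to compound 2 (0.32 log units; beyond the scatter), a modest step that concerns 3,4-dimethylphenyl in place of phenyl on an amide-type nitrogen. Compound 3, `Cc1cc(C#N)cc(C)c1Oc1ccnc(S(=O)(=O)CC(=O)Nc2cccc(F)c2)n1`, has not yet been measured. It differs from compound 1 by fluoro in place of hydrogen on an aromatic carbon. Among the compounds with values here, the single measured step touches the same aromatic group but is a different change, so it gives only a loose guide; nothing measured here speaks directly to a single fluoro on that ring. A small step, if any, is therefore expected. For compound 3 the estimated value in this assay is 25000 nM, with a range from 12000 nM to 50000 nM. The expected step, a 1.2-fold lower number from compound 1 to compound 3 (0.07 log units; within the scatter), is not anticipated to exceed the scatter.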

Compound 3, half-maximal cytotoxic concentration: 25900 nM
Estimate against measurement, compound 3: 1.0-fold (0.02 log units) below; low and high end bracket the measured number.
By their numbers in this assay, from the lowest: compounds 2, 3 and 1 (each within the scatter of the next, the first and the last beyond it).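

In this assay, putting 3-fluorophenyl in place of phenyl on the amide-type nitrogen gives a step within the scatter (a 1.1-fold lower number from compound 1 to compound 3 (0.05 log units; within the scatter)), so a single fluoro at this place on the ring cannot be told apart from hydrogen. Exchanging 3,4-dimethylphenyl for 3-fluorophenyl also stays within the scatter (a 1.9-fold higher number from compound 2 to compound 3 (0.27 log units; within the scatter)). Compound 3 therefore cannot be grouped with either compound 1 or compound 2, even though those two differ by more than the scatter.

The compounds shown leave open whether other groups at this place, such as an amine, a carboxylic acid or a longer chain, would also stay within the scatter of compound 1. The reason for these small steps also remains open, as no supporting measurement is available here.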